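From 4-(trifluoromethyl)phenyl to 2-(trifluoromethyl)phenyl on sulfur

This account rests on a few compounds, and the source may have more. Where it says the series, first, only, none or still open, it means among the compounds named here.

Measured in a functional assay on DU-145 cells (Homo sapiens) for antiproliferative activity, read by propidium iodide staining, with a stated time of 96 h; on this read-out lower numbers stand for stronger inhibition and higher numbers for weaker inhibition:
- compound 1 `CC(O)(CSc1cccc(S(F)(F)(F)(F)F)c1)C(=O)Nc1ccc(C#N)c(C(F)(F)F)c1` gives 32700 nM
- compound 2 `CC(O)(CSc1ccc(S(F)(F)(F)(F)F)cc1)C(=O)Nc1ccc(S(F)(F)(F)(F)F)cc1` gives 22300 nM
- compound 3 `CC(O)(CSc1ccc(C(F)(F)F)cc1)C(=O)Nc1ccc(S(F)(F)(F)(F)F)cc1` gives 28800 nM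

Compound 3 lies within the scatter of both compound 1 and compound 2, so the numbers set it apart from neither. Compound 4 `CC(O)(CSc1ccccc1C(F)(F)F)C(=O)Nc1ccc(S(F)(F)(F)(F)F)cc1` has the same atoms, joined differently. The change is 2-(trifluoromethyl)phenyl in place of 4-(trifluoromethyl)phenyl on a sulfur, with 2-(trifluoromethyl)phenyl in place of 4-(trifluoromethyl)phenyl on a sulfur. For the measured compounds named here, no measured step shows such a move. The closest one, a 1.3-fold higher number from compound 2 to compound 3 (0.11 log units; within the scatter), exchanges one group for another on that ring and stays within the scatter. In this assay no step beyond the scatter is therefore expected. The expected change is a 1.1-fold lower number from compound 3 to compound 4 (0.03 log units; within the scatter), which is no real shift. Compound 4 is estimated at 27000 nM, with an expected range from 13000 nM to 50000 nM.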

Compound 4, half-maximal inhibitory concentration: 15800 nM
Beside the measured number, compound 4's estimate is 1.7-fold (0.23 log units) above it; measured number inside the range.
By their numbers in this assay, from the lowest: compounds 4, 2, 3 and 1 (each within the scatter of the next, the first and the last beyond it).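

In this assay, the first move of the trifluoromethyl group around the ring on sulfur, with 2-(trifluoromethyl)phenyl in place of 4-(trifluoromethyl)phenyl, gives a 1.8-fold lower number from compound 3 to compound 4 (0.26 log units; within the scatter). The step stays within the scatter, so the numbers do not separate these two placements of the group. Nothing available explains the size of this step. The compounds shown leave open whether an amine or a carboxylic acid on this ring, or a longer chain on the sulfur, would give a step beyond the scatter.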